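Extending the amide alkyl group in a sulfonate ester series

The source may report more compounds than this note shows. Statements on the series, on what has been measured and on what is new or still open speak of the compounds shown alone.

Compound 3 `CC(=O)Nc1ccc(S(=O)(=O)Oc2ccccc2I)cc1` gives 27000 nM in a functional assay on M21 cells (Homo sapiens) for antiproliferative activity, read by sulforhodamine B assay, with a stated time of 48 h; a higher number here means a weaker inhibitor, a lower number a stronger inhibitor. Compound 1 `CC(=O)Nc1cccc(S(=O)(=O)Oc2ccccc2C(C)C)c1` gives 31000 nM, and compound 2 `CC(=O)Nc1ccc(S(=O)(=O)Oc2ccccc2C(C)C)cc1` gives 21000 nM; the move a 1.3-fold higher number from compound 2 to compound 3 (0.11 log units; within the scatter) lies within the scatter, and the gap between compound 3 and compound 1 does too, so compound 3 sits among its neighbours without a separable position. Compound 4 `CC(C)C(=O)Nc1ccc(S(=O)(=O)Oc2ccccc2I)cc1` differs from compound 3 by isopropyl in place of methyl on a carbonyl carbon, that is acetamido becoming (isopropylcarbonyl)amino. Within the data shown here, no measured pair alters this carbonyl substituent, and the one step that was measured, exchanging iodo for isopropyl on an aromatic carbon, stayed within the scatter. The step expected for compound 4, no change at the digits printed from compound 3 to compound 4 (within the scatter), is none beyond the scatter. The estimate for compound 4 in this assay is 27000 nM, within 11000 nM to 65000 nM.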

Compound 4, half-maximal inhibitory concentration: 13000 nM
Compound 4: middle estimate off by 2.1-fold (0.32 log units), on the high side, within the range that was stated.
By their numbers in this assay, from the lowest: compounds 4, 2, 3 and 1 (each within the scatter of the next, the first and the last beyond it).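

Isopropyl in place of methyl on a carbonyl carbon gives a 2.1-fold lower number from compound 3 to compound 4 (0.32 log units; beyond the scatter) in this assay and is a modest step, the only one shown that clears the scatter. The earlier step, iodo in place of isopropyl on an aromatic carbon, stayed within it, so the carbonyl substituent is the one place shown where a single change separates two compounds. Nothing available here explains this step.

Going by these compounds, it remains open whether a longer chain or a phenyl group on this carbonyl carbon would lower the number further. On these data alone, whether isopropylcarbonyl gives a similar step when isopropyl replaces iodo on the aromatic carbon also remains open.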